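From methoxymethyl to ethoxymethyl on the shared core

The compounds below may be only part of what the source reports. "The series", "measured", "known", "first", "only" and "open" are said of these compounds alone.

Compound 1 `Oc1c(CN2CCCC2)ccc2cccnc12`: 16600 nM
Compound 2 `Oc1c(CN2CCCC2)cc(Br)c2cccnc12`: 4270 nM
Compound 3 `COCc1cc(CN2CCCC2)c(O)c2ncccc12`: 52500 nM

In a functional assay on A-431 cells (Homo sapiens) for inhibition, with a stated time of 72 h (on this read-out higher numbers stand for weaker inhibition and lower numbers for stronger inhibition), compound 3 gives the highest number of the three, 52500 nM, which makes it the weakest inhibitor here. Compound 4 `CCOCc1cc(CN2CCCC2)c(O)c2ncccc12` differs from it by one small change: methyl in place of hydrogen on a saturated chain carbon bound to an oxygen on a saturated carbon, so methoxymethyl becomes ethoxymethyl. Two measured steps involve the methoxymethyl group: a modest one, a 3.2-fold higher number from compound 1 to compound 3 (0.50 log units; beyond the scatter), and a large one, a 12-fold higher number from compound 2 to compound 3 (1.09 log units; beyond the scatter). Among the compounds with values here, each swaps the whole group for hydrogen or bromo, a bigger edit than one added methyl, and no measured step lengthens this chain. In this assay, no step beyond the scatter is therefore expected, and no firm direction. The expected step is a 1.2-fold lower number from compound 3 to compound 4 (0.07 log units; within the scatter). Compound 4 is estimated at 45000 nM, with an expected range of 22000 nM to 90000 nM.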

Compound 4, half-maximal inhibitory concentration: 33100 nM
Estimate against measurement, compound 4: 1.4-fold (0.13 log units) above, and the stated range covers the measured number.
By their numbers in this assay, from the lowest: compound 2; then compounds 1, 4 and 3 (each within the scatter of the next, the first and the last beyond it).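

In this assay, lengthening methoxymethyl to ethoxymethyl gives a step within the scatter (a 1.6-fold lower number from compound 3 to compound 4 (0.20 log units; within the scatter)), so this added methyl shows no clear effect. Ethoxymethyl on the aromatic carbon also cannot be told apart from hydrogen (a 2.0-fold higher number from compound 1 to compound 4 (0.30 log units; within the scatter)), whereas bromo gives a clearly lower number, the sign of stronger inhibition (a 7.8-fold higher number from compound 2 to compound 4 (0.89 log units; beyond the scatter)).

As far as these compounds go, whether a longer chain such as propoxymethyl, or an amine such as aminomethyl, would shift the number in either direction remains open. The data shown offer no measurement that could explain these differences.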